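The source may hold more compounds than are shown below. What is called first, only, known or untested is meant among the compounds shown, and "the series" means these compounds.

Measured compounds:
- compound 1, `Cc1c(C(=O)NCc2ccccc2)[n+]([O-])c2ccccc2[n+]1[O-]`: in an ADME assay on Vero cells (Chlorocebus sabaeus) for cytotoxicity, read by MTT assay, with a stated time of 72 h (on this read-out higher numbers stand for weaker inhibition and lower numbers for stronger inhibition), compound 1 gives only a limit, > 100 ug/mL
- compound 2, `Cc1cc2c(cc1C)[n+]([O-])c(C(=O)NCc1ccccc1)c(C)[n+]2[O-]`: in this assay compound 2 gives "not determined" (no result reported)
- compound 3, `Cc1c(C(=O)NCc2ccccc2)[n+]([O-])c2cc(Cl)c(Cl)cc2[n+]1[O-]`: in this assay compound 3 gives only a limit, > 100 ug/mL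

Compound 1 therefore stands at the limit of this assay rather than at a number, and no single value places it relative to the others; the same limit holds for compound 3, and compound 2 carries no result. Within the data shown here, the shared pattern across the series is the limit of > 100 ug/mL in this assay, at which 2 of the 3 values shown sit, so nothing among the measured compounds ranks them.

Compound 4, `Cc1c(C(=O)NCc2ccccc2)[n+]([O-])c2cc(F)ccc2[n+]1[O-]`, differs from compound 1 by fluoro in place of hydrogen on an aromatic carbon, in words fluoro in place of hydrogen on an aromatic carbon. Among the measured compounds shown here, no measured step between compounds is available, so the expectation for compound 4 in this assay rests on the limits seen for compound 1 and compound 3. The step from compound 1 to compound 4 is expected to be none beyond the scatter, a step that the limit leaves unreadable from compound 1 to compound 4. Compound 4 is estimated at 150 ug/mL, within 60 ug/mL to 400 ug/mL, with the assay most likely reporting a limit again.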

Compound 4, half-maximal inhibitory concentration: > 100 ug/mL
Compound 4 gave a limit, no number; the forecaster's own chance of this, stated with the estimate: 80%; the middle value does not contradict the limit.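

Among these compounds, compound 1 and compound 4 both give only limits in this assay, so no step between them can be read. The compounds shown leave open any ranking and whether fluoro in place of hydrogen on an aromatic carbon shifts the value, with the series resting on one limit: the limit of > 100 ug/mL in this assay, at which 3 of the 4 values shown sit.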